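From trifluoromethyl to isopropyl on an aromatic carbon

A few compounds are considered here, and "the series" means these few. Any claim that something is new, unique, unknown or untested is made for them only; others in the source may bear on it.

Compound 1, `CC(C)C(=O)N(Cc1ccccc1C(F)(F)F)[C@H]1CCNC1`: "not determined" (no result reported) in an assay on HEK293 cells for inhibition of sodium-dependent dopamine transporter (Homo sapiens); a higher number here means a weaker inhibitor, a lower number a stronger inhibitor.
Compound 2, `CS(=O)(=O)N(Cc1ccccc1C(F)(F)F)[C@H]1CCNC1`: 2890 nM in this assay.

Compound 1 stands without a number of its own in this assay; no result was reported for it. The only measured anchor in this series is compound 2, which in this assay gives 2890 nM, a weak inhibition. Going by the values given here, no step between measured compounds is available, so nothing connects compound 1 to compound 2 beyond the fact that they share the same core and that compound 2 is weak.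

The step under consideration leads from compound 1 to compound 3, `CC(C)C(=O)N(Cc1ccccc1C(C)C)[C@H]1CCNC1`. The change is isopropyl in place of trifluoromethyl on an aromatic carbon. Since compound 1 has no value, the size of this step in this assay cannot be read from data; the expectation is that it stays within the scatter, with no clear direction, and that compound 3 lands near where compound 2 lies.

Compound 3 is therefore expected to give about 2500 nM in this assay, within a range from 400 nM to 15000 nM.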

Compound 3, inhibition constant: 3410 nM
Compound 3: the middle estimate sits 1.4-fold (0.13 log units) below what was measured, and the stated range covers the measured number.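

Compound 1 has no number to set against compound 3, so the step from trifluoromethyl to isopropyl cannot be read in this assay. No measured evidence bears on this result. The compounds shown leave open whether isopropyl in place of trifluoromethyl on this aromatic carbon changes the inhibition at all, and in which direction.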